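Swapping the amine-bearing side chain on the shared core

This account rests on a few compounds, and the source may have more. Where it says the series, first, only, none or still open, it means among the compounds named here.

Three compounds share one core, each carrying a trifluoromethyl group, a piperazine amide and an amine-bearing side chain on an aromatic carbon. Compound 1 `COc1cccc(CCC(=O)N2CCN(c3ccc(C(F)(F)F)cc3[C@@H](N)CC(C)C)CC2)c1` and compound 2 `CC(C)C[C@H](N)c1cc(C(F)(F)F)ccc1N1CCN(C(=O)CCc2cccs2)CC1` differ only in the aryl group at the end of the amide chain. In an assay on HEK293 cells for displacement of a labelled ligand from Melanocortin receptor 4 (Homo sapiens) (on this read-out higher numbers stand for weaker inhibition and lower numbers for stronger inhibition), compound 1 gives 4000 nM, and compound 2 gives 4600 nM; the step of a 1.2-fold higher number from compound 1 to compound 2 (0.06 log units; within the scatter) is too small to count as a real change. Compound 3 `CCC(C)CN[C@H](c1cc(C(F)(F)F)ccc1N1CCN(C(=O)CCc2ccc(Cl)cc2Cl)CC1)C(C)CC` carries a dichlorophenyl at the chain end and a larger side chain on the core; in this assay compound 3 gives 2800 nM, which sits within the scatter of both compound 1 and compound 2.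

Compound 4 `CCN[C@@H](CC(C)C)c1cc(C(F)(F)F)ccc1N1CCN(C(=O)CCc2ccc(Cl)cc2Cl)CC1` keeps the dichlorophenyl of compound 3 and changes only the side chain on the aromatic carbon: 1-(ethylamino)-3-methylbutyl in place of 2-methyl-1-((2-methylbutyl)amino)butyl on an aromatic carbon. For the measured compounds named here, no measured step touches this position, so none bears directly on the change. Going by the values given here, the only measured step, on the far side of the molecule, was within the scatter, and the three numbers all cluster closely. Compound 4 is therefore expected to stay in the same region, with an estimated step of a 1.3-fold higher number from compound 3 to compound 4 (0.10 log units; within the scatter) and no clear direction. The estimate for compound 4 in this assay is 3500 nM, ranging from 1200 nM to 10000 nM.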

Compound 4, inhibition constant: 170 nM
Compound 4: the middle estimate sits 21-fold (1.31 log units) above what was measured, outside the stated range (below it).
By their numbers in this assay, from the lowest: compound 4; then compounds 3, 1 and 2 (each within the scatter of the next).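

Compounds 3 and 4 differ only in the amine-bearing side chain, and in this assay putting 1-(ethylamino)-3-methylbutyl in place of 2-methyl-1-((2-methylbutyl)amino)butyl gives a 16-fold lower number from compound 3 to compound 4 (1.22 log units; beyond the scatter), which means stronger inhibition. For the compounds shown here, this is the first measured sign that this position on the aromatic carbon can move the number well beyond the scatter, since the only earlier step, at the far end of the amide chain, was a 1.2-fold higher number from compound 1 to compound 2 (0.06 log units; within the scatter). The side chain shrinks from 11 heavy atoms to 8 while the counts of hydrogen-bond donors and acceptors stay the same, but no measurement here explains why the number changes.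

This single step alters both the group on the amine nitrogen and the carbon chain that carries that nitrogen, so the compounds shown cannot tell which of the two accounts for the gain. As far as these compounds go, it also remains open how the number would respond with a methyl or a propyl group on that nitrogen, or with a cyclopropyl ring in the side chain.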